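Methoxy in place of nitro on the shared core

The source may hold more compounds than are shown below. What is called first, only, known or untested is meant among the compounds shown, and "the series" means these compounds.

Values in a functional assay on NCI-H460 cells (Homo sapiens) for cytotoxicity; a higher number here means a weaker inhibitor, a lower number a stronger inhibitor:
compound 1 `COc1ccc2nc(NC(=O)CCCCC(=O)NO)sc2c1`: 21.4 ug/mL
compound 2 `Cc1ccc2nc(NC(=O)CCCCCCC(=O)NO)sc2c1`: 0.84 ug/mL
compound 3 `O=C(CCCCCCC(=O)Nc1nc2ccc([N+](=O)[O-])cc2s1)NO`: 1.9 ug/mL

Compound 3 stands second highest of the three numbers, above compound 2 and well below compound 1. The next structure, compound 4 `COc1ccc2nc(NC(=O)CCCCCCC(=O)NO)sc2c1`, has methoxy in place of nitro on an aromatic carbon. The closest evidence is the modest 2.3-fold higher number from compound 2 to compound 3 (0.35 log units; beyond the scatter), with nitro in place of methyl. Among the measured compounds shown here, no measured pair isolates methoxy at this carbon. For the measured compounds named here, compound 1 also carries methoxy but differs from compound 4 elsewhere, so it offers no clean step. If methoxy tracks methyl rather than nitro, a modest move toward lower numbers is expected in this assay. The expected 1.7-fold lower number from compound 3 to compound 4 (0.24 log units; within the scatter) is of similar size to the measured step, in the opposite direction. Compound 4 is estimated at 1.1 ug/mL, with an expected range of 0.4 ug/mL to 3 ug/mL.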

Compound 4, half-maximal inhibitory concentration: 1.25 ug/mL
Compound 4: the middle estimate sits 1.1-fold (0.06 log units) below what was measured; low and high end bracket the measured number.
By their numbers in this assay, from the lowest: compounds 2, 4 and 3 (each within the scatter of the next, the first and the last beyond it); then compound 1.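

In this assay methoxy on this aromatic carbon is not separated from nitro, with a 1.5-fold lower number from compound 3 to compound 4 (0.18 log units; within the scatter), or from methyl, with a 1.5-fold higher number from compound 2 to compound 4 (0.17 log units; within the scatter); only methyl and nitro remain apart. With methoxy held fixed, the chain counts for far more: 2-(hydroxycarbamoyl)ethyl in place of hydroxycarbamoyl gives a 17-fold lower number from compound 1 to compound 4 (1.23 log units; beyond the scatter). No supporting data bear on either result.

From the compounds shown here alone, whether an amine or a carboxylic acid on this aromatic carbon would stay in the same range remains open. So does the effect of a chain longer than that of compound 4.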